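Replacing the sulfonyl group of compound 1

The source may hold more compounds than are shown below. What is called first, only, known or untested is meant among the compounds shown, and "the series" means these compounds.

Read-out: a functional assay on MKN-45 cells (Homo sapiens) for cytotoxicity; on this read-out lower numbers stand for stronger inhibition and higher numbers for weaker inhibition
- compound 1 `COc1ccc(S(=O)(=O)N2CCc3cccc(NS(=O)(=O)c4ccc(F)cc4)c32)cc1`: 890 nM
- compound 2 `COC(=O)c1ccc(C(=O)Nc2cccc3c2N(S(=O)(=O)c2ccc(OC)cc2)CC3)cc1`: 312 nM

Compound 1 holds the higher of the two numbers in this assay, and the gap to compound 2 lies beyond the scatter. Compound 3 (`COc1ccc(S(=O)(=O)N2CCc3cccc(NC(=O)c4ccncc4)c32)cc1`) has (pyridin-4-yl)carbonyl in place of (4-fluorophenyl)sulfonyl on a nitrogen on an aromatic ring. Going by the values given here, no measured pair isolates this change. Compound 2, at 312 nM, also holds a carbonyl on that nitrogen, so a move to a lower number is expected. The estimated step of a 22-fold lower number from compound 1 to compound 3 (1.35 log units; beyond the scatter) is expected to lie beyond the scatter. For compound 3 the estimated value is 40 nM, with an expected range from 6 nM to 300 nM.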

Compound 3, half-maximal inhibitory concentration: 8.8 nM
For compound 3 the middle estimate is 4.5-fold (0.66 log units) above the measured one, and the stated range covers the measured number.
By their numbers in this assay, from the lowest: compound 3; then compound 2; then compound 1.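

In this assay, the nitrogen on an aromatic ring proves a highly sensitive place: (pyridin-4-yl)carbonyl in place of (4-fluorophenyl)sulfonyl gives a 100-fold lower number from compound 1 to compound 3 (2.00 log units; beyond the scatter). With the carbonyl kept, pyridin-4-yl in place of 4-(methoxycarbonyl)phenyl gives a 35-fold lower number from compound 2 to compound 3 (1.55 log units; beyond the scatter), so the carbonyl alone does not account for the full step. Nothing available explains either step.

Still open, from the compounds shown here alone, is whether the pyridine ring nitrogen matters, and whether its place in the ring does; a plain phenyl or a pyridin-3-yl on the carbonyl carbon would address this.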